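The source may hold more compounds than are shown below. What is called first, only, known or untested is meant among the compounds shown, and "the series" means these compounds.

Compound 1 `COc1ccc2nc(C)cc(OCC(=O)Nc3cc(C)c(F)c(C)c3)c2c1`: > 100000 nM
Compound 2 `COc1ccc2nc(C)cc(OCC(=O)Nc3cc(C)nc(C)n3)c2c1`: > 100000 nM

In a toxicity assay on HepG2 cells (Homo sapiens) for inhibition, read by CellTiter-Glo, with a stated time of 48 h (on this read-out higher numbers stand for weaker inhibition and lower numbers for stronger inhibition), compound 1 gives only the limit > 100000 nM, which is a limit of the assay and not a number. Compound 2 likewise gives only the limit > 100000 nM. Both sit at the limit of > 100000 nM in this assay, at which 2 of the 2 values shown sit, so the step that the two limits leave unreadable from compound 1 to compound 2 cannot be read, and compound 2 stands at the limit itself. Compound 3 `COc1ccc2nc(C)cc(OCC(=O)NNC(=O)c3ccncc3)c2c1` carries ((pyridin-4-yl)carbonyl)amino in place of 2,6-dimethylpyrimidin-4-yl on an amide-type nitrogen. For the measured compounds named here, no measured step gives a readable size for such a change. The expected step that the limit leaves unreadable from compound 2 to compound 3 is therefore none beyond the scatter. Compound 3 is estimated at 150000 nM, within 50000 nM to 500000 nM, most likely again only a limit.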

Compound 3, half-maximal inhibitory concentration: > 100000 nM
Compound 3 gave a limit, no number; the forecaster's own chance of this, stated with the estimate: 80%; the middle value does not contradict the limit.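

In this assay, for the compounds shown here, compound 1, compound 2 and compound 3 each give only a limit of the assay, not a number, so no step among them can be read: the limit of > 100000 nM in this assay, at which 3 of the 3 values shown sit. The compounds shown leave open at what concentration, if any, these compounds inhibit the cells, and whether the group on the amide-type nitrogen changes that.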